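Carbonyl substituent swap in the diacetoxy cinnamoyl series

This account rests on a few compounds, and the source may have more. Where it says the series, first, only, none or still open, it means among the compounds named here.

Compound 1 `C#CCCOC(=O)/C=C/c1ccc(OC(C)=O)c(OC(C)=O)c1` gives 1800 nM in an assay for inhibition of Polyunsaturated fatty acid 5-lipoxygenase (Homo sapiens), read by HPLC, with a stated time of 10 min; a lower number here means a stronger inhibitor, a higher number a weaker inhibitor.
Compound 2 `C#CCCCCCOC(=O)/C=C/c1ccc(OC(C)=O)c(OC(C)=O)c1` gives 470 nM in this assay.
Compound 3 `C#CCCNC(=O)/C=C/c1ccc(OC(C)=O)c(OC(C)=O)c1` gives 8230 nM in this assay.

Compound 3 holds the highest number of the three: a 4.6-fold higher number from compound 1 to compound 3 (0.66 log units; beyond the scatter) and an 18-fold higher number from compound 2 to compound 3 (1.24 log units; beyond the scatter) both lead to it, each beyond the scatter. Compound 4 `CC(=O)Oc1ccc(/C=C/C(=O)CCCN=[N+]=[N-])cc1OC(C)=O` differs from compound 3 by a group of 6 heavy atoms (3 carbon, 3 nitrogen; no ring) in place of a group of 5 heavy atoms (4 carbon, 1 nitrogen; no ring), on a carbonyl carbon. Among the measured compounds shown here, no measured step exchanges the nitrogen-bearing group on the carbonyl carbon for a carbon chain, so the two steps ending at compound 3 bear only loosely, as does a 3.8-fold lower number from compound 1 to compound 2 (0.58 log units; beyond the scatter) on chain length. A tentative expectation follows: a modest step toward a lower number, a 2.7-fold lower number from compound 3 to compound 4 (0.44 log units; beyond the scatter), is expected. Compound 4 is accordingly estimated at 3000 nM, with a range of 800 nM to 12000 nM.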

Compound 4, half-maximal inhibitory concentration: 1300 nM
Beside the measured number, compound 4's estimate is 2.3-fold (0.36 log units) above it; low and high end bracket the measured number.
By their numbers in this assay, from the lowest: compound 2; then compounds 4 and 1 (each within the scatter of the next); then compound 3.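

On the carbonyl carbon, an oxygen link is not needed for this level of inhibition: 3-azidopropyl, which carries no such link, cannot be separated from (but-3-yn-1-yl)oxy, with a 1.4-fold lower number from compound 1 to compound 4 (0.14 log units; within the scatter). The same group clearly outperforms the nitrogen-linked chain, with a 6.3-fold lower number from compound 3 to compound 4 (0.80 log units; beyond the scatter), but does not match the longer ester chain, with a 2.8-fold higher number from compound 2 to compound 4 (0.44 log units; beyond the scatter). No measurement available here explains these differences.

Going by these compounds, it remains open whether the azide itself matters or only the chain carrying it. A longer azidoalkyl chain or a plain alkyl ketone would help separate the two.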